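This account rests on a few compounds, and the source may have more. Where it says the series, first, only, none or still open, it means among the compounds named here.

For the measured compounds named here, compound 1 `C=CC1=C(C(=O)NC2CCCCC2)C(c2ccc(OC)cc2)OC1` is the only member of this small set that gives a single number in a functional assay on HeLa cells (Homo sapiens) for cytotoxicity, read by MTT assay, with a stated time of 24 h (a higher number here means a weaker inhibitor, a lower number a stronger inhibitor), where compound 1 gives 24800 nM. Its fluoro analogue, compound 3 `C=CC1=C(C(=O)NC2CCCCC2)C(c2ccc(F)cc2)OC1`, reaches only the limit of the assay, and in this assay compound 3 gives > 100000 nM. The step from compound 1 to compound 3 is an at least 4.0-fold higher number from compound 1 to compound 3 (0.60 log units; beyond the scatter), and it rests on (the limit of > 100000 nM in this assay, at which 1 of the 3 values shown sits). Compound 2 `C=CC1=C(C(=O)Nc2cccc(C)c2)C(c2ccc(F)cc2)OC1`, which pairs the fluoro group with an aryl amide, is recorded in this assay as "not active" (no number reported).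

Compound 4 `C=CC1=C(C(=O)NCC(C)C)C(c2ccc(OC)cc2)OC1` keeps the methoxy group of compound 1 and alters only the amide side: isobutyl in place of cyclohexyl on an amide-type nitrogen. Going by the values given here, none of the measured steps touches this position; the one step that is known concerns the aromatic substituent, so it offers no direct guide to what an isobutyl in place of cyclohexyl on the amide nitrogen will do. The expectation for compound 4 is therefore a step of a 1.2-fold higher number from compound 1 to compound 4 (0.08 log units; within the scatter) in this assay, which is not expected to go beyond the scatter in either direction. Compound 4 is accordingly estimated at 30000 nM, with a range from 10000 nM to 100000 nM.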

Compound 4, half-maximal inhibitory concentration: > 100000 nM
Compound 4: a limit, no number; the forecaster's own chance of this, stated with the estimate: 30%; at least 3.3-fold (0.52 log units) between middle value and limit.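

In this assay, for the compounds shown here, isobutyl in place of cyclohexyl on the amide nitrogen gives an at least 4.0-fold higher number from compound 1 to compound 4 (0.60 log units; beyond the scatter), so the amide side, which no earlier step touched, matters as well as the aromatic substituent. Compound 4 gives > 100000 nM, which is a limit of the assay and not a number. Among these compounds, only compound 1, with its cyclohexyl and methoxy groups together, gives a single number, and each of the two single changes away from it ends at the same limit, so the true size of both steps stays unknown: the limit of > 100000 nM in this assay, at which 2 of the 4 values shown sit.

The compounds shown do not separate the loss of the ring from the change in the size of the group, since cyclohexyl to isobutyl alters both at once, and a cyclopentyl group, a cyclohexylmethyl group or an unbranched butyl chain on the same nitrogen would bear on that question. They also leave open whether any group on this nitrogen, or an amine or a carboxylic acid in place of the methoxy group, would give a lower number than compound 1 does.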